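The source may report more compounds than this note shows. Statements on the series, on what has been measured and on what is new or still open speak of the compounds shown alone.

Compound 3 `N=C(N)N/N=C/c1c(-c2ccsc2)nc2sccn12` gives 28800 nM in a functional assay on cells (Cancer cell lines, Homo sapiens) for inhibition; on this read-out lower numbers stand for stronger inhibition of growth and higher numbers for weaker inhibition of growth. It sits alongside compound 2 `Cc1cn2c(/C=N/NC(=N)N)c(-c3ccsc3)nc2s1`, which gives 20000 nM, and compound 1 `Cc1cc(-c2nc3sc(C)cn3c2/C=N/NC(=N)N)c(C)s1`, which gives 19100 nM, all three within the scatter of one another. The two measured steps, a 1.0-fold higher number from compound 1 to compound 2 (0.02 log units; within the scatter) and a 1.4-fold higher number from compound 2 to compound 3 (0.16 log units; within the scatter), each altered groups around the shared core without moving the number beyond the scatter. Compound 4 `N=C(N)N/N=C/c1c(-c2cccs2)nc2sccn12` differs from compound 3 by thiophen-2-yl in place of thiophen-3-yl on an aromatic carbon. Going by the values given here, no measured step exchanges one attachment point of this group for another, so the earlier steps bear only loosely, and on their showing the expectation is no step beyond the scatter in this assay , a 1.0-fold lower number from compound 3 to compound 4 (0.01 log units; within the scatter). Compound 4 is therefore estimated at 28000 nM, within a range from 12000 nM to 65000 nM.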

Compound 4, concentration for total growth inhibition: 24500 nM
Compound 4: middle estimate off by 1.1-fold (0.06 log units), on the high side; the measured number falls inside the stated range.
By their numbers in this assay, from the lowest: compounds 1, 2, 4 and 3 (each within the scatter of the next).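

The only step shown that exchanges one attachment point of the thiophene for another, thiophen-2-yl in place of thiophen-3-yl, gives a 1.2-fold lower number from compound 3 to compound 4 (0.07 log units; within the scatter) in this assay. At this position, on an aromatic carbon next to the ring nitrogen, the same atoms joined differently therefore do not separate the two compounds on this read-out. Nothing at hand explains this result.

On these data alone, all four compounds carry a thiophene here, so it remains open whether a phenyl ring or a simple amine at this position would move the number beyond the scatter.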